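The source may hold more compounds than are shown below. What is called first, only, known or untested is meant among the compounds shown, and "the series" means these compounds.

Measured in an ADME assay on HEp-2 cells (Homo sapiens) for cytotoxicity; a higher number here means that more compound is tolerated, a lower number that less compound is tolerated:
- compound 1, `CNCc1ccc2c(c1)nc(Cn1c(=O)n(C(C)C)c3ccccc31)n2CCC(C)C`: 1480 nM
- compound 2, `CC(C)CCn1c(Cn2c(=O)n(CC(=O)O)c3ccccc32)nc2cc(C(=N)N)ccc21`: 173000 nM
- compound 3, `C=C(C)n1c(=O)n(Cc2nc3cc(/C(N)=N\O)ccc3n2CCC(C)C)c2ccccc21`: 3470 nM

Compound 1 stands lowest of the three in this assay, that is, it is the least tolerated. Compound 3 sits above it by a gap beyond the usual scatter, and compound 2 lies far above both. Going by the values given here, no two of these three differ in a single place, so no single structural step within the measured set can be read off; the gaps say only that changes at the substituent on the fused six-membered ring and at the group on the cyclic urea nitrogen go together with wide differences in tolerated concentration.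

Compound 4, `CC(C)CCn1c(Cn2c(=O)n(C(C)C)c3ccccc32)nc2cc(N)ccc21`, is not yet measured. It differs from compound 1 in one place: amino in place of (methylamino)methyl on an aromatic carbon. Nothing measured here carries this exact change, so the expectation rests on the position of compound 1 alone. Because compound 1 gives 1480 nM, the lowest number of the set, the step from compound 1 to compound 4 is expected to be small and upward, a 1.7-fold higher number from compound 1 to compound 4 (0.23 log units; within the scatter), not clearly beyond the scatter. For compound 4 the expected value in this assay is 2500 nM, with a range from 800 nM to 8000 nM.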

Compound 4, half-maximal cytotoxic concentration: 32200 nM
The estimate for compound 4 lay 13-fold (1.11 log units) below the measured number; the measured number lies above the stated range.
By their numbers in this assay, from the lowest: compound 1; then compound 3; then compound 4; then compound 2.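

In this assay the substituent on this aromatic carbon can now be read on its own: with amino in place of (methylamino)methyl and the rest of the core of compound 1 unchanged, the step is a 22-fold higher number from compound 1 to compound 4 (1.34 log units; beyond the scatter) and is large. The earlier compounds shown here differed in more than one place, so they could not separate this substituent from the group on the cyclic urea nitrogen, whereas this pair shows that the change at this position alone goes with a wide gap in tolerated concentration. The counts of hydrogen-bond donors and acceptors match between the two groups and neither carries a net charge, leaving the drop from 3 heavy atoms to 1 as the computed difference, and nothing at hand explains the step.

Still open, on these data alone, is which part of the (methylamino)methyl group goes with the low number: aminomethyl, dimethylamino or a plain methyl on the same aromatic carbon would divide the change into smaller parts. As far as these compounds go, it is also open whether a step of this size holds when another group, such as a longer alkyl chain or a carboxylic acid, sits on the cyclic urea nitrogen.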